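From Cyclohexyl to Cycloheptyl in a Growth Inhibition Series

The source may report more compounds than this note shows. Statements on the series, on what has been measured and on what is new or still open speak of the compounds shown alone.

Of the compounds shown here, two have so far been measured in a functional assay on HT-29 cells (Homo sapiens) for inhibition, read by sulforhodamine B assay, with a stated time of 48 h; on this read-out lower numbers stand for stronger inhibition of growth and higher numbers for weaker inhibition of growth. Compound 1 (`c1cc(OC2CCCCCC2)ccc1NC1=NCCO1`) gives 16600 nM in this test, while compound 2 (`O=C(CCl)NC(=O)Nc1ccc(OC2CCCCC2)cc1`) gives 3100 nM in the same test. Compound 2 therefore stands at the lower of the two numbers, and the gap between them lies beyond the usual scatter. Compound 3 (`O=C(CCl)NC(=O)Nc1ccc(OC2CCCCCC2)cc1`) has cycloheptyl in place of cyclohexyl on an oxygen on an aromatic ring and otherwise matches compound 2. Going by the values given here, no measured pair isolates this change, so any forecast of its size remains uncertain. The expected step of a 1.2-fold lower number from compound 2 to compound 3 (0.09 log units; within the scatter) is small, slightly towards a lower number and not beyond the scatter. For compound 3 the estimated value is 2500 nM, with an expected range from 1000 nM to 6000 nM.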

Compound 3, concentration for 50% growth inhibition: 2300 nM
The estimate for compound 3 lay 1.1-fold (0.04 log units) above the measured number, and the stated range covers the measured number.
By their numbers in this assay, from the lowest: compounds 3 and 2 (each within the scatter of the next); then compound 1.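

In this assay, going by these compounds alone, the step of a 1.3-fold lower number from compound 2 to compound 3 (0.13 log units; within the scatter) gives the first direct reading at this position, on an oxygen on an aromatic ring: cycloheptyl in place of cyclohexyl produces no change beyond the scatter. With cycloheptyl held constant, replacing the group on a nitrogen on an aromatic ring gives a 7.2-fold lower number from compound 1 to compound 3 (0.86 log units; beyond the scatter) and this single-place comparison shows a modest difference beyond the scatter. No available evidence bears on the reason for either step.

The compounds shown leave open whether a smaller cyclopentyl ring or an open hexyl chain on the oxygen would fit the same flat picture. They also leave open whether the chlorine in the group on the nitrogen matters, which a methyl in its place would test.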